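Urea aryl swap: from nitrophenyl back to halogenated phenyl

The compounds below may be only part of what the source reports. "The series", "measured", "known", "first", "only" and "open" are said of these compounds alone.

Measured compounds:
compound 1, `COc1cc(Nc2ncnc3c(NC(=O)Nc4ccccc4Cl)cccc23)cc(OC)c1`, 356 nM
compound 2, `COc1cc(Nc2ncnc3c(NC(=O)Nc4ccc([N+](=O)[O-])cc4)cccc23)cc(OC)c1`, > 20000 nM

In a functional assay on RT-112 cells (Homo sapiens) for antiproliferative activity, read by MTT assay, with a stated time of 72 h (a lower number here means a stronger inhibitor of growth, a higher number a weaker inhibitor of growth), compound 1 gives 356 nM. For compound 2 the result is only a limit of this assay, > 20000 nM, so compound 2 stands at the weak edge of the data, at the limit of > 20000 nM in this assay, at which 1 of the 2 values shown sits. Among the measured compounds shown here, the one measured step, an at least 56-fold higher number from compound 1 to compound 2 (1.74 log units; beyond the scatter), goes the wrong way for growth inhibition.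

Compound 3, `COc1cc(Nc2ncnc3c(NC(=O)Nc4ccc(Cl)c(Cl)c4)cccc23)cc(OC)c1`, is not yet measured. It differs from compound 2 as 3,4-dichlorophenyl in place of 4-nitrophenyl on an amide-type nitrogen. The measured step bears on it only in reverse: removing the 4-nitrophenyl that cost so much, and bringing in chlorine, which compound 1 carries with its value of 356 nM. A large recovery is therefore expected, an at least 25-fold lower number from compound 2 to compound 3 (1.39 log units; beyond the scatter), though the limit on compound 2 leaves its true size uncertain. Compound 3 is estimated at 800 nM, with a range from 150 nM to 8000 nM.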

Compound 3, concentration for 50% growth inhibition: 6230 nM
Beside the measured number, compound 3's estimate is 7.8-fold (0.89 log units) below it, and the stated range covers the measured number.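

Compound 2 holds only a limit of this assay, > 20000 nM, and this governs how its step is read: the limit of > 20000 nM in this assay, at which 1 of the 3 values shown sits. Within that reading, the change on the amide-type nitrogen gives an at least 3.2-fold lower number from compound 2 to compound 3 (0.50 log units; beyond the scatter), so 3,4-dichlorophenyl brings a value inside the measured range of this assay where 4-nitrophenyl did not. Chlorine on the phenyl ring does not by itself hold the stronger growth inhibition, however: the change from 2-chlorophenyl to 3,4-dichlorophenyl gives an 18-fold higher number from compound 1 to compound 3 (1.24 log units; beyond the scatter), which shows that this position distinguishes between two chlorinated phenyl groups.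

On these data alone, what remains open is whether the second chlorine or the place of the chlorines accounts for that loss. A plain phenyl, a 4-chlorophenyl or a 2-fluorophenyl group on this nitrogen would help to separate these readings.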